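The source may report more compounds than this note shows. Statements on the series, on what has been measured and on what is new or still open speak of the compounds shown alone.

For the measured compounds named here, the three compounds measured so far share one core and differ only in the aryl group on the amide carbonyl. Compound 1 `O=C(Nc1cccc(-c2oc3cc(-c4ccc(F)cc4)ccc3c(=O)c2O)c1)c1ccccc1F` gives 17400 nM in a functional assay on GTL 16 cells for antiproliferative activity against GTL 16 cell line (Homo sapiens), read by CCK-8 assay, with a stated time of 72 h; on this read-out higher numbers stand for weaker inhibition and lower numbers for stronger inhibition. Compound 2 `Cc1ccc(C(=O)Nc2cccc(-c3oc4cc(-c5ccc(F)cc5)ccc4c(=O)c3O)c2)cc1` gives 12900 nM in this assay, and compound 3 `O=C(Nc1cccc(-c2oc3cc(-c4ccc(F)cc4)ccc3c(=O)c2O)c1)c1ccc(Cl)cc1` gives 9140 nM in this assay. Compound 3 thus carries the lowest of the three numbers shown, but both of its steps from the others stay within the scatter: a 1.9-fold lower number from compound 1 to compound 3 (0.28 log units; within the scatter) and a 1.4-fold lower number from compound 2 to compound 3 (0.15 log units; within the scatter). Compound 4 `O=C(Nc1cccc(-c2oc3cc(-c4ccc(F)cc4)ccc3c(=O)c2O)c1)c1ccc(C(F)(F)F)cc1` has not yet been measured; it differs from compound 3 by trifluoromethyl in place of chloro on an aromatic carbon. The step most like this change is a 1.4-fold lower number from compound 2 to compound 3 (0.15 log units; within the scatter), where chloro replaced methyl on an aromatic carbon, and the exchange of the whole aryl group, a 1.3-fold lower number from compound 1 to compound 2 (0.13 log units; within the scatter), was likewise within the scatter. Since every substituent change on this ring has so far moved the number only within the scatter, no step beyond it is expected in this assay, the expected step being a 1.1-fold lower number from compound 3 to compound 4 (0.06 log units; within the scatter). Compound 4 is therefore estimated at 8000 nM in this assay, with a range from 3000 nM to 20000 nM.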

Compound 4, half-maximal inhibitory concentration: 33000 nM
For compound 4 the middle estimate is 4.1-fold (0.62 log units) below the measured one; measured number above the stated range.
By their numbers in this assay, from the lowest: compounds 3, 2, 1 and 4 (each within the scatter of the next, the first and the last beyond it).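

For the compounds shown here, at this position, para to a large group, trifluoromethyl is the first substituent to move the number beyond the scatter in this assay, with modest steps from both chloro (a 3.6-fold higher number from compound 3 to compound 4 (0.56 log units; beyond the scatter)) and methyl (a 2.6-fold higher number from compound 2 to compound 4 (0.41 log units; beyond the scatter)), so the ring position is not indifferent to what it carries. The comparison with the 2-fluorophenyl amide stays within the scatter (a 1.9-fold higher number from compound 1 to compound 4 (0.28 log units; within the scatter)), so this exchange of the whole aryl group separates the two compounds no more than repeat measurements would. Nothing shown here accounts for the different reading of trifluoromethyl.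

The compounds shown leave open how an amine, a carboxylic acid or a methoxy group would read at this position. They also leave open whether trifluoromethyl in place of chloro would give a similar step on another core.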